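The source may hold more compounds than are shown below. What is called first, only, known or untested is meant among the compounds shown, and "the series" means these compounds.

Compound 1, `Cc1ccc(-c2nn(-c3ccc(Br)cc3)c(/N=C/N(C)C)c2C=O)cc1`, gives 6700 nM in a functional assay on Jurkat cells (Homo sapiens) for inhibition, read by MTT assay, with a stated time of 72 h; a lower number here means a stronger inhibitor of growth, a higher number a weaker inhibitor of growth. Compound 2, `Cc1ccc(-c2nn(-c3cccc(Cl)c3)c(N)c2C=O)cc1`, gives 86300 nM in this assay.

Of these two numbers, compound 2 stands highest; its nearest neighbour is compound 1, whose number is lower by an amount beyond the usual scatter. Compound 3, `Cc1ccc(-c2nn(-c3ccc(Br)cc3)c(N)c2C=O)cc1`, differs from compound 2 in one place: 4-bromophenyl in place of 3-chlorophenyl on an aromatic nitrogen. Among the measured compounds shown here, no two measured compounds differ in only this way, so the size of this step in this assay is not known from the data; compound 1 also carries the 4-bromophenyl but differs in another place too. A small step toward a lower number is expected, a 2.2-fold lower number from compound 2 to compound 3 (0.33 log units; beyond the scatter), possibly within the scatter. Compound 3 is therefore estimated at 40000 nM, in a range from 10000 nM to 150000 nM.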

Compound 3, concentration for 50% growth inhibition: 34400 nM
Compound 3: middle estimate off by 1.2-fold (0.07 log units), on the high side, within the range that was stated.
By their numbers in this assay, from the lowest: compound 1; then compound 3; then compound 2.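

The change from 3-chlorophenyl to 4-bromophenyl on the aromatic nitrogen now has a measured size in this assay (a 2.5-fold lower number from compound 2 to compound 3 (0.40 log units; beyond the scatter)), a modest step. With 4-bromophenyl held fixed, the group on the aromatic carbon can also be read alone: the amino group in place of the larger group of 5 heavy atoms gives a modest step the other way (a 5.1-fold higher number from compound 1 to compound 3 (0.71 log units; beyond the scatter)). No measurement at hand explains either step.

Going by these compounds, whether the halogen or its place on the phenyl ring matters stays open, and a 4-chlorophenyl or a 3-bromophenyl would separate the two. On these data alone, how an acetamide on that aromatic carbon would compare also remains unknown.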